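The source may report more compounds than this note shows. Statements on the series, on what has been measured and on what is new or still open speak of the compounds shown alone.

Working notes on the series: in a functional assay on MCF7 cells (Homo sapiens) for antiproliferative activity, read by MTT assay, with a stated time of 48 h (on this read-out lower numbers stand for stronger inhibition and higher numbers for weaker inhibition), compound 1 `Clc1ccc(-c2nn(-c3ccccc3)cc2-c2nc3ccccc3[nH]2)cc1` gives 3030 nM and compound 2 `Fc1ccc2[nH]c(-c3cn(-c4ccccc4)nc3-c3ccc(Cl)cc3)nc2c1` gives 2830 nM. Within the data shown here, only these two numbers exist so far, and compound 2 stands level with its single neighbour: a 1.1-fold lower number from compound 1 to compound 2 (0.03 log units; within the scatter).

The next structure is compound 3 `Clc1ccc(-c2nn(-c3ccccc3)cc2-c2nc3cc(Br)ccc3[nH]2)cc1`, reached from compound 2 by bromo in place of fluoro on an aromatic carbon. This puts bromo in place of fluoro on an aromatic carbon of a six-membered aromatic ring of carbon only, part of a fused or bridged system of two rings.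

Among the measured compounds shown here, one measured step bears on this site, fluoro in place of hydrogen, and it stayed within the scatter. For the measured compounds named here, no bromo compound has been measured, so the basis is thin. No shift beyond the scatter is expected in this assay. The estimated step is a 1.1-fold lower number from compound 2 to compound 3 (0.05 log units; within the scatter). Compound 3 is expected at 2500 nM, with an estimated range of 1000 nM to 6000 nM.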

Compound 3, half-maximal inhibitory concentration: 1920 nM
Beside the measured number, compound 3's estimate is 1.3-fold (0.11 log units) above it, within the range that was stated.
By their numbers in this assay, from the lowest: compounds 3, 2 and 1 (each within the scatter of the next).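

Working notes, continued: in this assay, this site on the six-membered aromatic ring of carbon only has now carried hydrogen, fluoro and bromo. Bromo stays within the scatter against fluoro (a 1.5-fold lower number from compound 2 to compound 3 (0.17 log units; within the scatter)) and against hydrogen (a 1.6-fold lower number from compound 1 to compound 3 (0.20 log units; within the scatter)). The earlier pair covered fluoro alone, whereas these steps show that a second halogen at this position also gives no shift that can be told from repeat measurements, leaving compound 1, compound 2 and compound 3 level. No independent measurement is available to explain this outcome.

Still open, from the compounds shown here alone, is whether a group of another kind at this site, such as an amine, a carboxylic acid or a longer chain, would move the number beyond the scatter. Going by these compounds, whether the level result holds on other cells also remains open.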